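The source may report more compounds than this note shows. Statements on the series, on what has been measured and on what is new or still open speak of the compounds shown alone.

Of the compounds shown here, two have been tested so far in an assay on cells for inhibition of thyroid peroxidase (Homo sapiens), with stated times of 10 min and 15 min; a lower number here means a stronger inhibitor, a higher number a weaker inhibitor. Compound 1 `Nc1cc(Cc2ccn(-c3ccc(F)cc3)n2)c2nn[nH]c2n1` gives 700 nM. Compound 2 `Nc1cc(Cc2ccn(Cc3cccc(Oc4cccc5c4CNC5)c3)n2)c2nn[nH]c2n1`, which carries a much larger group on its pyrazole nitrogen, gives 1700 nM, the higher of the two numbers, and its distance from compound 1 lies beyond the usual scatter of this assay, so compound 2 is the weaker inhibitor of the pair.

Compound 3 `Nc1cc(Cc2ccn(Cc3ccccc3)n2)c2nn[nH]c2n1` is the next compound to be measured. It is obtained from compound 2 by one change: a hydrogen atom in place of a group of 10 heavy atoms (8 carbon, 1 nitrogen, 1 oxygen; one five-membered non-aromatic ring with 1 hetero atom, one six-membered aromatic ring of carbon only), on an aromatic carbon. The remainder of the molecule, including the shared core and the benzyl group on the pyrazole, is unchanged.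

Going by the values given here, no pair of measured compounds differs in exactly this way, so there is no directly comparable step to lean on. Among the compounds with values here, the only guidance is that compound 1, which carries a smaller group at the same position, gives the lower number. On that basis the step from compound 2 to compound 3 is expected to be modest, most likely toward a lower number, and quite possibly within the scatter: a 1.3-fold lower number from compound 2 to compound 3 (0.12 log units; within the scatter). Compound 3 is therefore estimated at 1300 nM, with a plausible range from 400 nM to 5000 nM.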

Compound 3, half-maximal inhibitory concentration: 2300 nM
Estimate against measurement, compound 3: 1.8-fold (0.25 log units) below; the range from low to high includes it.
By their numbers in this assay, from the lowest: compound 1; then compounds 2 and 3 (each within the scatter of the next).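

In this assay, taking the group of 10 heavy atoms off the aromatic carbon and leaving a hydrogen atom gives a 1.4-fold higher number from compound 2 to compound 3 (0.13 log units; within the scatter) and so leaves two compounds that cannot be told apart; the large group therefore shows no measurable contribution to the number in this assay. With that group gone, compound 1 and compound 3 differ in one place only, and benzyl in place of 4-fluorophenyl on an aromatic nitrogen gives a 3.3-fold higher number from compound 1 to compound 3 (0.52 log units; beyond the scatter) as a modest step, the first one beyond the scatter that can be tied to a single place. That single swap alters both the fluorine and the carbon link of the benzyl group at once, and nothing shown explains either step.

From the compounds shown here alone, it remains open whether the fluorine or the link matters more, which a plain phenyl or a 4-fluorobenzyl group on the same nitrogen would help to settle. Going by these compounds, it is also open whether a small group on the aromatic carbon, such as an amine or a carboxylic acid, would move the number at all.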